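From bromo to trifluoromethoxy at the assay limit

The source may hold more compounds than are shown below. What is called first, only, known or untested is meant among the compounds shown, and "the series" means these compounds.

In a functional assay on MCF cells (Homo sapiens) for antiproliferative activity, with a stated time of 72 h (a higher number here means a weaker inhibitor, a lower number a stronger inhibitor), compound 1 `OC[C@H]1O[C@@H](n2cnc3c(NCc4ccccc4Cl)ncnc32)[C@H](O)[C@@H]1O` gives > 166000 nM, which is a limit of the assay and not a number. Compound 2 `OC[C@H]1O[C@@H](n2cnc3c(NCc4ccccc4Br)ncnc32)[C@H](O)[C@@H]1O` gives > 166000 nM, which is again a limit. Compound 2 therefore has no readable potency, and the two compounds together show (the limit of > 166000 nM in this assay, at which 2 of the 2 values shown sit). Compound 3 `OC[C@H]1O[C@@H](n2cnc3c(NCc4ccccc4OC(F)(F)F)ncnc32)[C@H](O)[C@@H]1O` keeps the shared core and carries trifluoromethoxy in place of bromo on an aromatic carbon, ortho to a large group: trifluoromethoxy in place of bromo on an aromatic carbon. Going by the values given here, the one measured step, a step that the two limits leave unreadable from compound 1 to compound 2, gives no size to carry over, so the expectation is weak: no clear gain in this assay, with a result near the same limit quite likely. The estimated change is a step that the limit leaves unreadable from compound 2 to compound 3. Compound 3 is expected at about 170000 nM, with an estimated range from 60000 nM to 400000 nM.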

Compound 3, half-maximal inhibitory concentration: > 166000 nM
Compound 3 gave a limit, no number; the forecaster's own chance of this, stated with the estimate: 75%; the middle value is on the limit's open side.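

No step between compound 1, compound 2 and compound 3 can be read, since each result is a limit of the assay and not a number: the limit of > 166000 nM in this assay, at which 3 of the 3 values shown sit.

Going by these compounds, how chloro, bromo and trifluoromethoxy on this shared core compare in potency therefore stays open.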